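Changing the Halogen Pattern on the Aromatic Nitrogen Substituent

The compounds below may be only part of what the source reports. "The series", "measured", "known", "first", "only" and "open" are said of these compounds alone.

Compound 1 `O=C(Nc1ccc(Oc2ncnc3ccsc23)c(F)c1)c1nn(-c2ccc(F)cc2)ccc1=O` gives 8230 nM in a functional assay on A549 cells (Homo sapiens) for cytotoxicity, read by MTT assay, with a stated time of 72 h; a lower number here means a stronger inhibitor, a higher number a weaker inhibitor.
Compound 2 `O=C(Nc1ccc(Oc2ncnc3ccsc23)c(F)c1)c1nn(-c2ccc(F)c(Cl)c2)ccc1=O` gives 9650 nM in this assay.

Compound 2 is placed relative to compound 1 only by a 1.2-fold higher number from compound 1 to compound 2 (0.07 log units; within the scatter), so the two numbers cannot be told apart. Compound 3 `O=C(Nc1ccc(Oc2ncnc3ccsc23)c(F)c1)c1nn(-c2ccc(Br)cc2)ccc1=O` differs from compound 2 by 4-bromophenyl in place of 3-chloro-4-fluorophenyl on an aromatic nitrogen. Going by the values given here, the one measured step that touches this part of the molecule, a 1.2-fold higher number from compound 1 to compound 2 (0.07 log units; within the scatter), shows that adding a chloro on an aromatic carbon of this ring left the result within the scatter. Among the compounds with values here, no measured step exchanges fluorine for bromine, so that part of the change has no direct precedent. Given this, the change from compound 2 to compound 3 is expected to stay within the scatter, a 1.1-fold lower number from compound 2 to compound 3 (0.03 log units; within the scatter). Compound 3 is therefore estimated at 9000 nM, with a range from 4000 nM to 20000 nM.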

Compound 3, half-maximal inhibitory concentration: 7840 nM
Beside the measured number, compound 3's estimate is 1.1-fold (0.06 log units) above it; the range from low to high includes it.
By their numbers in this assay, from the lowest: compounds 3, 1 and 2 (each within the scatter of the next).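

In this assay, going by these compounds alone, this is the first direct reading of bromo in place of fluoro on the phenyl group carried by the ring nitrogen, and that exchange stays within the scatter (a 1.0-fold lower number from compound 1 to compound 3 (0.02 log units; within the scatter)). The larger change, 4-bromophenyl in place of 3-chloro-4-fluorophenyl, removes one halogen and exchanges another, yet it also stays within the scatter (a 1.2-fold lower number from compound 2 to compound 3 (0.09 log units; within the scatter)), so the three halogen patterns cannot be told apart at this position. No evidence is at hand that could explain why the three numbers lie so close together.

As far as these compounds go, all three compounds carry only halogens on this phenyl group, so it remains open whether an amine or a carboxylic acid there would shift the number beyond the scatter. A plain phenyl group without any halogen, on the same shared core, also remains an open comparison.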